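Replacing isobutyl with cyclobutyloxy on the carbonyl carbon

The source may hold more compounds than are shown below. What is called first, only, known or untested is meant among the compounds shown, and "the series" means these compounds.

Three compounds with a shared core differ only in the ring on a saturated ring carbon. Compound 1 `CC1=C(C(=O)CC(C)C)C(c2ccco2)NC(=O)N1` gives 31% in an assay on membranes from HeLa cells for displacement of a labelled ligand from adenosine receptor A3 (Homo sapiens), read by scintillation counting, with a stated time of 180 min, tested at 1 uM; a lower number here means less inhibition, a higher number more inhibition at the concentration tested (going by the name of the read-out). Compound 2 `CC1=C(C(=O)CC(C)C)C(c2ccoc2)NC(=O)N1` gives 18%, and compound 3 `CC1=C(C(=O)CC(C)C)C(c2cccs2)NC(=O)N1` gives 18%, in this assay. Compound 3 thus sits level with compound 2 at the foot of the three, below compound 1: a number 13 percentage points lower from compound 1 to compound 3 (beyond the scatter), while no change at the digits printed from compound 2 to compound 3 (within the scatter).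

Compound 4 `CC1=C(C(=O)OC2CCC2)C(c2cccs2)NC(=O)N1` keeps the thiophen-2-yl of compound 3 and changes elsewhere: cyclobutyloxy in place of isobutyl on a carbonyl carbon. Among the measured compounds shown here, none of the measured steps touches the carbonyl carbon, so no measured step bears on this change and its size is unknown; the estimate stays near compound 3 with a wide range. Compound 4 is expected at 20%, between 5% and 45%, an expected step of a number 2 percentage points higher from compound 3 to compound 4 (within the scatter).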

Compound 4, a percentage reported as inhibition, at one concentration (the size of the read-out at that concentration, not a potency): 2%
The estimate for compound 4 lay 18 percentage points above the measured number, outside the stated range (below it).
By their numbers in this assay, from the lowest: compound 4; then compounds 2 and 3 (each within the scatter of the next); then compound 1.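

Among the compounds shown here, the carbonyl carbon, which the earlier compounds left unchanged, also affects the result in this assay: cyclobutyloxy in place of isobutyl gives a number 16 percentage points lower from compound 3 to compound 4 (beyond the scatter). This swap adds an oxygen and a four-membered ring together, so this single step cannot separate their contributions. No measured evidence explains the drop.

On these data alone, it remains open whether an open-chain ethoxy or an amine on the carbonyl carbon would give a similar number. As far as these compounds go, whether cyclobutyloxy would lower the number with the furan-2-yl of compound 1 also remains unknown.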